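The compounds below may be only part of what the source reports. "The series", "measured", "known", "first", "only" and "open" are said of these compounds alone.

Going by the values given here, compound 1, with structure `O=C(CO[C@@H]1C[C@@H](CNc2ccccn2)N(C(=O)OCc2ccccc2)C1)NC[C@H](NC(=O)c1ccccc1)C(=O)O`, is one of two compounds measured in an assay on a protein complex for inhibition of integrin alpha-5/beta-1 (Homo sapiens), read by ELISA; a lower number here means a stronger inhibitor, a higher number a weaker inhibitor; in this assay compound 1 gives 155 nM. Among the compounds with values here, compound 2, with structure `COc1ccnc(NC[C@@H]2C[C@@H](OCC(=O)NC[C@H](NC(=O)c3c(C)cc(C)cc3C)C(=O)O)CN2C(=O)OCc2ccccc2)c1`, is the only other compound with a number, and in this assay compound 2 gives 0.54 nM. Of the two, compound 1 therefore stands at the higher number, and the gap to compound 2 lies beyond the usual scatter. Within the data shown here, compound 2 differs from compound 1 in more than one place, so the two values show only that the compounds sit far apart, not what any single change contributes.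

Compound 3, with structure `CC1(C(=O)N[C@@H](CNC(=O)CO[C@@H]2C[C@@H](CNc3ccccn3)N(C(=O)OCc3ccccc3)C2)C(=O)O)CCCCC1`, has not yet been measured. It differs from compound 1 in one place: 1-methylcyclohexyl in place of phenyl on a carbonyl carbon. Among the measured compounds shown here, no measured pair shows this change on its own, so the size and direction of the step are open. In this assay compound 3 is expected to come in near 80 nM, within a range of 20 nM to 400 nM. The step from compound 1 to compound 3 is thus estimated to be a 1.9-fold lower number from compound 1 to compound 3 (0.29 log units; within the scatter), a modest gain that could still fall inside the scatter.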

Compound 3, half-maximal inhibitory concentration: 1.7 nM
For compound 3 the middle estimate is 47-fold (1.67 log units) above the measured one; the whole stated range lies above it.
By their numbers in this assay, from the lowest: compound 2; then compound 3; then compound 1.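

In this assay, the group on this carbonyl carbon weighs heavily: with the rest of compound 1 unchanged, 1-methylcyclohexyl in place of phenyl gives a 91-fold lower number from compound 1 to compound 3 (1.96 log units; beyond the scatter) and so puts a single change behind a large step. The two earlier compounds differ in more than one place and could show no such thing; this pair shows that an aromatic ring of carbon only is not required at this position for a low number, since a non-aromatic six-membered ring of carbon only serves far better here. No measurement of any property of these two groups bears on the result. The compounds shown leave open whether the step belongs to the methyl group or to the non-aromatic ring, which a plain cyclohexyl or a tert-butyl on the same carbonyl carbon would begin to separate. They also leave open whether 1-methylcyclohexyl brings a step of similar size when other parts of the molecule change, as they do in compound 2.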